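The source may report more compounds than this note shows. Statements on the series, on what has been measured and on what is new or still open speak of the compounds shown alone.

Of the compounds shown here, three built on one shared core have been tested in a functional assay on HCT-116 cells (Homo sapiens) for cytotoxicity, read by MTT assay, with a stated time of 24 h; a higher number here means a weaker inhibitor, a lower number a stronger inhibitor. Compound 1 `COc1ccc(/C=C\C(=O)O)c(OCc2cn(-c3ccc(NC(=O)c4ccccc4)cc3)nn2)c1CC=C(C)C` gives 16400 nM. Compound 2 `COc1ccc(/C=C\C(=O)O)c(OCc2cn(-c3ccc(CO)cc3)nn2)c1CC=C(C)C` gives 31700 nM. Compound 3 `COc1ccc(/C=C\C(=O)O)c(OCc2cn(-c3ccccc3C(=O)N3CCC(O)C3)nn2)c1CC=C(C)C` gives 32000 nM. The numbers for compound 2 and compound 3 are essentially identical, and the gap from compound 2 to compound 1 also lies within the usual scatter, so compound 2 sits in a group of three values that cannot be told apart. Among the compounds with values here, the only measured step, a 1.9-fold higher number from compound 1 to compound 2 (0.29 log units; within the scatter), changes the group carried by the phenyl ring attached to the five-membered aromatic ring with three nitrogens, and it stayed within the scatter.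

Compound 4 `COc1ccc(/C=C\C(=O)O)c(OCc2cn(-c3ccccc3C#N)nn2)c1CC=C(C)C` has not yet been measured. It differs from compound 2 by 2-cyanophenyl in place of 4-(hydroxymethyl)phenyl on an aromatic nitrogen. This is the same part of the molecule touched by the step from compound 1 to compound 2, and compound 3, which carries yet another group on that ring, also lands in the same range. A change of about a 1.1-fold lower number from compound 2 to compound 4 (0.02 log units; within the scatter) is therefore expected, that is nothing beyond the scatter. Compound 4 is estimated to give 30000 nM, with a likely range from 12000 nM to 80000 nM.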

Compound 4, half-maximal inhibitory concentration: 38300 nM
Compound 4: middle estimate off by 1.3-fold (0.11 log units), on the low side; the measured number falls inside the stated range.
By their numbers in this assay, from the lowest: compounds 1, 2, 3 and 4 (each within the scatter of the next, the first and the last beyond it).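

Replacing 4-(hydroxymethyl)phenyl with 2-cyanophenyl on the aromatic nitrogen removes the hydrogen-bond donor from this group, yet in this assay the result is a 1.2-fold higher number from compound 2 to compound 4 (0.08 log units; within the scatter). Cyano in place of (3-hydroxypyrrolidin-1-yl)carbonyl on an aromatic carbon, a swap of a much larger group for a nitrile, gives a 1.2-fold higher number from compound 3 to compound 4 (0.08 log units; within the scatter), so these two quite different replacements also leave the number within the scatter. Nothing available explains why these values stay so close. On these data alone, whether an amine or a sulfonamide on this phenyl ring would give a step beyond the scatter remains open. All four compounds share the same core, so they also leave open how much a change elsewhere in the molecule would matter.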